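A few compounds are considered here, and "the series" means these few. Any claim that something is new, unique, unknown or untested is made for them only; others in the source may bear on it.

Compound 2 `CC(C)N(Cc1cccc(OCCCCCC(=O)O)c1)C(=O)c1ccccc1` is the starting point. In an ADME assay on HEK293 cells (Homo sapiens) for cytotoxicity, read by CellTiter-Glo and resazurin assay, with a stated time of 72 h (a lower number here means that less compound is needed, a higher number that more compound is needed for the effect), compound 2 gives > 26000 nM, which is a limit rather than a number. Compound 1 `CC(C)N(Cc1cccc(OCCCCCC(=O)O)c1)C(=O)c1ccc(-c2cccc(N(C)C)c2)cc1` gives > 26000 nM, again a limit. Compound 3 `CC(C)N(Cc1cccc(OCCCCCC(=O)O)c1)C(=O)c1ccc(-c2cccc(-c3ccccc3)c2)cc1` gives > 26000 nM, also a limit. Compound 4 `CC(C)N(Cc1cccc(OCCCCCC(=O)O)c1)C(=O)c1ccc(-c2ccsc2)cc1` is the new member. The change from compound 2 to compound 4 is thiophen-3-yl in place of hydrogen on an aromatic carbon. The closest measured step, a step that the two limits leave unreadable from compound 2 to compound 3, puts a larger aromatic group on the same aromatic carbon, but its size cannot be read because of the limit of > 26000 nM in this assay, at which 3 of the 3 values shown sit. The steps a step that the two limits leave unreadable from compound 1 to compound 2 and a step that the two limits leave unreadable from compound 1 to compound 3 are likewise unreadable. No readable step therefore sizes the expected change a number no higher from compound 2 to compound 4 (the limit leaves the size open). Compound 4 is estimated in this assay at 26000 nM, most likely reported again as a limit, within 13000 nM to 100000 nM.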

Compound 4, half-maximal effective concentration: > 26000 nM
Compound 4: no number, only a limit; the forecaster's own chance of this, stated with the estimate: 85%; the middle value sits exactly at the limit.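

No new step can be read between compound 4 and compound 1, compound 2 or compound 3 in this assay because all four compounds sit at the same limit: the limit of > 26000 nM in this assay, at which 4 of the 4 values shown sit. In this assay the concentration at which any of these compounds reaches its half-maximal effect stays open.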